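This account rests on a few compounds, and the source may have more. Where it says the series, first, only, none or still open, it means among the compounds named here.

Measured in a functional assay on MCF7 cells (Homo sapiens) for antiproliferative activity, read by MTT assay, with a stated time of 48 h; a higher number here means a weaker inhibitor, a lower number a stronger inhibitor:
- compound 1 `COc1ccc(C(=O)c2ccc(OC)c3c2OC(C)(C)C=C3)c(NC(=O)CBr)c1` gives 2360 nM in this list
- compound 2 `COc1ccc(C(=O)c2ccc(OC)c3c2C=CC(C)(C)O3)c(NC(=O)CBr)c1` gives 3290 nM in this list
- compound 3 `COc1ccc(C(=O)c2ccc3c(c2)C=CC(C)(C)O3)c(NC(=O)CO)c1` gives 200 nM in this list

Compound 1 stands level with compound 2, within the usual scatter of repeated measurements, while compound 3 shows a clearly lower number, and so stronger inhibition, than either.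

Compound 4 `CNCC(=O)Nc1cc(OC)ccc1C(=O)c1ccc(OC)c2c1OC(C)(C)C=C2` has not yet been measured. It comes from compound 1 through a single change (methylamino in place of bromo on a saturated chain carbon bound to a carbonyl carbon), with methylamino in place of bromo on a saturated chain carbon bound to a carbonyl carbon.

For the measured compounds named here, no measured pair shows this swap on its own, so the guidance is thin. Compound 3 also lacks bromo and gives 200 nM in this assay, but its core differs from that of compound 1, which makes it only a loose guide.

A small move toward a lower number is expected, estimated as a 1.8-fold lower number from compound 1 to compound 4 (0.26 log units; within the scatter) in this assay, and that may not clear the scatter. For compound 4 the estimated value is 1300 nM with an expected range from 250 nM to 7000 nM in this measurement.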

Compound 4, half-maximal inhibitory concentration: 820 nM
Compound 4: middle estimate off by 1.6-fold (0.20 log units), on the high side; the measured number falls inside the stated range.
By their numbers in this assay, from the lowest: compound 3; then compound 4; then compounds 1 and 2 (each within the scatter of the next).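

The bromo group on this saturated chain carbon bound to a carbonyl carbon is not needed for antiproliferative activity in this assay because replacing it with methylamino gives a 2.9-fold lower number from compound 1 to compound 4 (0.46 log units; beyond the scatter) and the activity is kept. For the compounds shown here, this modest step is the first direct reading of this position, as none of the earlier compounds formed a pair differing in one place. The data offer no measurement that explains the change.

From the compounds shown here alone, how an unsubstituted amine, a dimethylamino group or a longer chain carrying the amine would compare at this place remains open. Also open, going by these compounds, is whether methylamino in place of bromo would give a similar step on the core of compound 2.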